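The source may hold more compounds than are shown below. What is called first, only, known or untested is meant among the compounds shown, and "the series" means these compounds.

Compound 1: `CCCOc1cccc(C(=O)Nc2cccc(C(=O)O)c2)c1`, 2150 nM 
Compound 2: `CC(C)COc1cccc(C(=O)Nc2cccc(C(=O)O)c2)c1`, 1130 nM 
Compound 3: `CC(C)COc1ccc(C(=O)Nc2cccc(C(=O)O)c2)cc1`, 357 nM 

These three compounds were measured in an assay on isolated protein for agonist activity at Bile acid receptor (Homo sapiens), read by TR-FRET, with a stated time of 3 h, in the absence of a further agent; a lower number here means that less compound is needed, a higher number that more compound is needed for the effect. Compound 3 stands with the lowest number of the three; compound 2 comes nearest, and compound 1 is furthest away, both gaps lying beyond the scatter. Within the data shown here, the only step that changes a single place, a 1.9-fold lower number from compound 1 to compound 2 (0.28 log units; within the scatter), adds a methyl to the chain and stays within the scatter. Compound 2 and compound 3 differ in where the isobutoxy sits on the ring, and their values differ beyond the scatter.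

Compound 4, `O=C(O)c1cccc(NC(=O)c2ccc(-c3ccccc3)cc2)c1`, has not yet been measured in this assay. It differs from compound 3 by phenyl in place of isobutoxy on an aromatic carbon. Among the measured compounds shown here, no measured step replaces the isobutoxy with a ring, so none bears directly on this change; the one measured step was small. The estimate for compound 4 in this assay is therefore 600 nM, with a range from 150 nM to 2500 nM, which means an expected step of a 1.7-fold higher number from compound 3 to compound 4 (0.23 log units; within the scatter), a modest move in either direction.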

Compound 4, half-maximal effective concentration: > 10000 nM
Compound 4: only a limit was reported; the forecaster's own chance of this, stated with the estimate: 5%; at least 16-fold (1.22 log units) between middle value and limit.
By their numbers in this assay, from the lowest: compound 3; then compounds 2 and 1 (each within the scatter of the next). At a limit, above all of these: compound 4.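

Replacing isobutoxy with phenyl on an aromatic carbon para to a large group gives an at least 28-fold higher number from compound 3 to compound 4 (1.44 log units; beyond the scatter) in this assay. Compound 4 gives > 10000 nM, which is a limit of the assay and not a number: the limit of > 10000 nM in this assay, at which 1 of the 4 values shown sits. The earlier compounds shown here showed a change within the chain that stayed within the scatter, whereas this exchange of the whole group at this position shows that the value in this assay can depend strongly on which group sits there.

The compounds shown do not separate the loss of the ether oxygen from the entry of the aromatic ring. A phenoxy group, which holds both the oxygen and the ring, or a butyl chain, which holds neither, would bear on that question at this position.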